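Swapping a Pyridine for a Chlorinated Phenyl Ring

The source may report more compounds than this note shows. Statements on the series, on what has been measured and on what is new or still open speak of the compounds shown alone.

Compound 3 `Cc1nn(-c2nc(-c3ccc(Cl)c(Cl)c3)c(SC(C)C)s2)c(C(=O)O)c1-c1ccncc1` stands lowest of the three measured numbers in a functional assay on BJAB cells (Homo sapiens) for antiproliferative activity, with a stated time of 4 days (a higher number here means that more compound is needed for the effect, a lower number that less compound is needed), giving 5900 nM, though all three sit within the scatter of one another. Compound 2 `Cc1nn(-c2nc(-c3ccc(Cl)c(Cl)c3)c(SC(C)C)s2)c(C(=O)O)c1-c1cnn(C)c1` gives 6800 nM and compound 1 `CCOc1ncccc1-c1c(C)nn(-c2nc(-c3ccc(Cl)c(Cl)c3)c(SC(C)C)s2)c1C(=O)O` gives 11000 nM; the steps of a 1.6-fold lower number from compound 1 to compound 2 (0.21 log units; within the scatter), a 1.9-fold lower number from compound 1 to compound 3 (0.27 log units; within the scatter) and a 1.2-fold lower number from compound 2 to compound 3 (0.06 log units; within the scatter) are all small, so these three aromatic groups cannot be told apart. Compound 4 `Cc1cc(Cl)cc(-c2c(C)nn(-c3nc(-c4ccc(Cl)c(Cl)c4)c(SC(C)C)s3)c2C(=O)O)c1` differs from compound 3 by 3-chloro-5-methylphenyl in place of pyridin-4-yl on an aromatic carbon. Among the measured compounds shown here, no measured step removes the single hydrogen-bond acceptor or brings in a chlorine, but the three exchanges of one aromatic group for another that bear on this change were all within the scatter. A small step is therefore expected, with a 1.5-fold lower number from compound 3 to compound 4 (0.17 log units; within the scatter). Compound 4 is estimated at 4000 nM, within 1500 nM to 12000 nM.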

Compound 4, half-maximal effective concentration: 663 nM
For compound 4 the middle estimate is 6.0-fold (0.78 log units) above the measured one; the whole stated range lies above it.
By their numbers in this assay, from the lowest: compound 4; then compounds 3, 2 and 1 (each within the scatter of the next).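

In this assay the 3-chloro-5-methylphenyl group gives an 8.9-fold lower number from compound 3 to compound 4 (0.95 log units; beyond the scatter) and a 10-fold lower number from compound 2 to compound 4 (1.01 log units; beyond the scatter) and also a 17-fold lower number from compound 1 to compound 4 (1.22 log units; beyond the scatter) even though the three earlier aromatic groups could not be told apart. This position is therefore not indifferent to the aromatic group it carries. Nothing available explains the gain.

The compounds shown leave open whether the chlorine, the methyl or the carbon-only ring accounts for the step. A plain phenyl ring, or a phenyl ring bearing only a chlorine or only a methyl, would separate these.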